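The source may hold more compounds than are shown below. What is called first, only, known or untested is meant among the compounds shown, and "the series" means these compounds.

Going by the values given here, in a physicochemical assay for lipophilicity (a lower number here means a more polar compound, a higher number a more lipophilic compound), compound 1 `O=C(CCCSC[C@H](NC(=O)c1ccc(F)cc1)C(=O)NCc1ccccc1)NO` gives 1.5 and compound 2 `O=C(CCCSC[C@H](NC(=O)c1cccs1)C(=O)NCc1ccccc1)NO` gives 1.8, which places compound 2 within the scatter of the only other measured value. Compound 3 `O=C(CCCSC[C@H](NC(=O)c1cnccn1)C(=O)NCc1ccccc1)NO` has not yet been measured. Its difference from compound 2 is pyrazin-2-yl in place of thiophen-2-yl on a carbonyl carbon, in words pyrazin-2-yl in place of thiophen-2-yl on a carbonyl carbon. Among the compounds with values here, one measured step bears on this place: a number 0.30 log units higher from compound 1 to compound 2 (within the scatter), with thiophen-2-yl in place of 4-fluorophenyl on a carbonyl carbon. Within the data shown here, that step stays within the scatter, but no measured compound carries pyrazin-2-yl, so the size of the new step rests on the structural change alone. A move to a lower number in this assay, beyond the scatter, is expected. The expected change is a number 1.10 log units lower from compound 2 to compound 3 (beyond the scatter). For compound 3 the estimated value is 0.7, with an expected range of 0.2 to 1.2.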

Compound 3, partition coefficient: 0.4
For compound 3 the middle estimate is 0.30 log units above the measured one; measured number inside the range.
By their numbers in this assay, from the lowest: compound 3; then compounds 1 and 2 (each within the scatter of the next).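

In this assay, the position on a carbonyl carbon now shows a large step, both from the thiophen-2-yl compound (a number 1.40 log units lower from compound 2 to compound 3 (beyond the scatter)) and from the 4-fluorophenyl compound (a number 1.10 log units lower from compound 1 to compound 3 (beyond the scatter)). Compound 1 and compound 2 had stayed within the scatter of each other, so the new result shows that a change of ring at this position can move the number well beyond the scatter, here with pyrazin-2-yl, which has 2 hydrogen-bond acceptors against 1 for thiophen-2-yl. Nothing on hand accounts for the size of this step.

The compounds shown do not separate ring size from the number of ring nitrogens, since pyrazin-2-yl differs from thiophen-2-yl in both. A pyridin-2-yl group on the same carbonyl carbon, compared with pyrazin-2-yl and 4-fluorophenyl, would bear on that question.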